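The compounds below may be only part of what the source reports. "The series", "measured", "known", "first", "only" and "open" are said of these compounds alone.

In a functional assay on MES-SA/Dx5 cells (Homo sapiens) for inhibition, with a stated time of 72 h, in the presence of a further agent that is not named here (a higher number here means a weaker inhibitor, a lower number a stronger inhibitor), compound 3 (`COCc1cc(CN2CCC(C)CC2)c(O)c2ncccc12`) gives 4680 nM and sits within the usual scatter of compound 1 (`CCOCc1cc(CN2CCCC2)c(O)c2ncccc12`), which gives 5250 nM as its number. Compound 2 (`CC1CCN(Cc2cc(Cl)c3cccnc3c2O)CC1`) gives 1590 nM; 1580 nM (2 entries) from its repeat entries. Compound 4 (`CCOCc1cc(CN2CCC(C)CC2)c(O)c2ncccc12`) differs from compound 3 in one place (methyl in place of hydrogen on a saturated chain carbon bound to an oxygen on a saturated carbon), where methoxymethyl becomes ethoxymethyl. Within the data shown here, no pair of measured compounds shows this change alone. A step within the scatter is expected in this assay because compound 1 with its ethoxymethyl gives 5250 nM within the scatter of compound 3. The estimated step is a 1.0-fold lower number from compound 3 to compound 4 (0.02 log units; within the scatter) in size. The expected value for compound 4 is 4500 nM (range 2200 nM to 9000 nM).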

Compound 4, half-maximal inhibitory concentration: 3020 nM
Estimate against measurement, compound 4: 1.5-fold (0.17 log units) above; low and high end bracket the measured number.
By their numbers in this assay, from the lowest: compounds 4, 3 and 1 (each within the scatter of the next).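

In this assay the change from methoxymethyl to ethoxymethyl now has a direct reading, a 1.5-fold lower number from compound 3 to compound 4 (0.19 log units; within the scatter) and so the added methyl leaves the number within the scatter. With ethoxymethyl held fixed, the change from pyrrolidin-1-yl to 4-methylpiperidin-1-yl also stays within it, at a 1.7-fold lower number from compound 1 to compound 4 (0.24 log units; within the scatter) for that swap of the amine ring. Repeat entries for a single compound can agree closely: the several entries of compound 2 in this assay, 1590 nM; 1580 nM (2 entries). From the compounds shown here alone, whether a longer chain such as butoxymethyl would give a step beyond the scatter stays open. So does the effect of placing a carboxylic acid at this position.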